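Benzyl to Propargyl: An Expected Small Step

This account rests on a few compounds, and the source may have more. Where it says the series, first, only, none or still open, it means among the compounds named here.

Among the measured compounds shown here, in a functional assay on HL-60 cells (Homo sapiens) for cytotoxicity, read by MTT assay, with a stated time of 24 h (on this read-out higher numbers stand for weaker inhibition and lower numbers for stronger inhibition), compound 1 `BrCCCOc1c(Br)cc(Br)cc1Oc1ccc(Br)cc1Br` gives 29.9 ug/mL and compound 2 `Brc1ccc(Oc2cc(Br)cc(Br)c2OCc2ccccc2)c(Br)c1` gives 27.9 ug/mL, so compound 2 stands level with the only other measured compound. Compound 3 `C#CCOc1c(Br)cc(Br)cc1Oc1ccc(Br)cc1Br` carries ethynyl in place of phenyl on a saturated chain carbon bound to an oxygen on an aromatic ring. For the measured compounds named here, the one measured step at this place is a 1.1-fold lower number from compound 1 to compound 2 (0.03 log units; within the scatter), which put phenyl in place of 2-bromoethyl. On that evidence, no change beyond the scatter is expected in this assay. The expected step is a 1.0-fold lower number from compound 2 to compound 3 (0.01 log units; within the scatter). For compound 3 the estimated value is 27 ug/mL, with an expected range of 12 ug/mL to 55 ug/mL.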

Compound 3, half-maximal inhibitory concentration: 29.7 ug/mL
Beside the measured number, compound 3's estimate is 1.1-fold (0.04 log units) below it, within the range that was stated.
By their numbers in this assay, from the lowest: compounds 2, 3 and 1 (each within the scatter of the next).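

In this assay, ethynyl in place of phenyl gives a 1.1-fold higher number from compound 2 to compound 3 (0.03 log units; within the scatter), and ethynyl in place of 2-bromoethyl gives a 1.0-fold lower number from compound 1 to compound 3 (0.00 log units; within the scatter). The aromatic ring can thus leave this saturated chain carbon, and a triple bond can enter there, with all three compounds staying within the scatter of one another. No available evidence accounts for this level reading. Going by these compounds, whether an amine or a carboxylic acid at this place would also read level remains open, as does whether a longer chain would.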